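The source may report more compounds than this note shows. Statements on the series, on what has been measured and on what is new or still open speak of the compounds shown alone.

Read-out in a functional assay on NCI-H460 cells (Homo sapiens) for antiproliferative activity, read by CCK-8 assay, with a stated time of 72 h, tested at 8 uM (on this read-out lower numbers stand for a weaker effect and higher numbers for a stronger effect at the one concentration tested), for the measured compounds:

compound 1 `CC(C)n1cnc2c(Nc3ccccc3)nc(NCOCc3ccc(C(=O)Nc4ccccc4N)cc3)nc21`: 34.3%
compound 2 `CC(C)n1cnc2c(NCc3ccc(C(=O)Nc4ccccc4N)cc3)nc(Cl)nc21`: 80.5%
compound 3 `Nc1ccccc1NC(=O)c1ccc(CNc2nc(Cl)nc3c2ncn3C2CCCC2)cc1`: 57.4%

Compound 2 and compound 3 differ in one place: cyclopentyl in place of isopropyl on an aromatic nitrogen. On that change the read-out moved a number 23.1 percentage points lower from compound 2 to compound 3 (beyond the scatter). The difference between the cores of compound 1 and compound 2 is not broken down here; compound 1 stands lowest of the three in this assay.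

Compound 4 `Nc1ccccc1NC(=O)c1ccc(COCNc2nc(Nc3ccccc3)c3ncn(C4CCCC4)c3n2)cc1` has not been measured. From compound 1 it differs by cyclopentyl in place of isopropyl on an aromatic nitrogen, the same change as between compound 2 and compound 3. Compound 4 is expected to sit somewhat below compound 1 in this assay, the estimate resting on the measured step of a number 23.1 percentage points lower from compound 2 to compound 3 (beyond the scatter); because compound 1 starts from 34.3%, the expected step of a number 17.3 percentage points lower from compound 1 to compound 4 (beyond the scatter) is taken as somewhat smaller than the earlier one. Compound 4 is estimated at 17%, likely between 3% and 35%.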

Compound 4, a percentage reported as inhibition, at one concentration (the size of the read-out at that concentration, not a potency): 56.1%
For compound 4 the middle estimate is 39.1 percentage points below the measured one, outside the stated range (above it).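

In this assay, cyclopentyl in place of isopropyl on an aromatic nitrogen moved the read-out a number 21.8 percentage points higher from compound 1 to compound 4 (beyond the scatter), so the change does not carry over with a fixed direction from one core to the other: the same change on two cores in this assay, a number 23.1 percentage points lower (beyond the scatter) from compound 2 to compound 3 and a number 21.8 percentage points higher (beyond the scatter) from compound 1 to compound 4, 44.9 percentage points apart, beyond the scatter of two such steps In this series, a step measured on one core is therefore a poor guide to the step on another. These two pairs do not show which difference between the cores goes with the reversal, as compound 1 and compound 2 differ in more than one place, and they give no rule for other cores.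

Still open, on these data alone, is whether cyclobutyl, cyclohexyl or a longer chain on that aromatic nitrogen would split the two cores in the same way. Also open, as far as these compounds go, is how an amine in place of the chlorine of compound 3 would respond to the same change.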